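Chloro to Cyano on the Benzyl Group

The source may hold more compounds than are shown below. What is called first, only, known or untested is meant among the compounds shown, and "the series" means these compounds.

Compound 2 `Nc1nc(O)c2c(n1)n(C1OC(CO)[C@@H](O)[C@H]1O)c(=O)n2Cc1ccc(Cl)cc1` gives the lower of the two maximal responses recorded in a functional assay on YAC-1 cells (Mus musculus) (on this read-out lower numbers stand for smaller maximal responses and higher numbers for larger maximal responses), at 27%, while compound 1 `C=CCn1c(=O)n(C2C[C@H](O)C(CO)O2)c2nc(N)nc(O)c21` reaches 75%, a gap beyond the usual scatter. Compound 3 `N#Cc1ccc(Cn2c(=O)n(C3OC(CO)[C@@H](O)[C@H]3O)c3nc(N)nc(O)c32)cc1` differs from compound 2 by a single change: cyano in place of chloro on an aromatic carbon. Within the data shown here, no measured pair shows this same exchange, so its effect cannot be read from the data. A small step is expected, in no sure direction, as a number 8 percentage points higher from compound 2 to compound 3 (within the scatter) shows. Compound 3 is thus estimated to reach about 35% in this assay, between 15% and 60%.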

Compound 3, largest response reached (reported as maximal response), in percent of the reference or control that the assay uses: 0%
Compound 3: the middle estimate sits 35 percentage points above what was measured, outside the stated range (below it).
By their numbers in this assay, from the lowest: compound 3; then compound 2; then compound 1.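

Exchanging 4-chlorobenzyl for 4-cyanobenzyl gives a number 27 percentage points lower from compound 2 to compound 3 (beyond the scatter) in this assay, so this position is not indifferent to the group it carries. Among these compounds, this is the first pair that differs in one place, and so the first direct reading of a single change here. Nothing at hand tells what lies behind this step.

From the compounds shown here alone, whether an amine or a carboxylic acid in the same place would give a response as low as that of compound 3 stays open. Going by these compounds, it is also open whether cyano in place of chloro has a similar effect on other benzyl-bearing compounds.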